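The source may hold more compounds than are shown below. What is called first, only, known or untested is meant among the compounds shown, and "the series" means these compounds.

The measured compounds and their values:

Compound 1, `N#Cc1cnc(NCc2cnccc2C(F)(F)F)cc1N[C@H]1C[C@@H](O)C1`, gives > 10000 nM.
Compound 2, `N#Cc1cnc(NCc2cncnc2C(F)(F)F)cc1N[C@H]1CC[C@@H](O)CC1`, gives 450 nM.
Compound 3, `CC1(C)[C@H](O)C[C@@H]1Nc1nc(NCc2cnccc2C(F)(F)F)ncc1C#N`, gives 8500 nM.

These numbers come from an assay on isolated protein for inhibition of protein kinase C delta type (Homo sapiens), read by TR-FRET, with a stated time of 2 h; on this read-out higher numbers stand for weaker inhibition and lower numbers for stronger inhibition. Compound 1 returns only a limit there, (the limit of > 10000 nM in this assay, at which 1 of the 3 values shown sits), so no number is known for it. Compound 2 gives 450 nM and compound 3 gives 8500 nM, and between those two values compound 2 shows the lower number.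

The piece follows the step from compound 1 to compound 4, `CC1(C)[C@@H](C(N)=O)C[C@H]1Nc1cc(NCc2cnccc2C(F)(F)F)ncc1C#N`, which has yet to be measured in this assay. The change is 3-carbamoyl-2,2-dimethylcyclobutyl in place of 3-hydroxycyclobutyl on a nitrogen on an aromatic ring. The two cyclobutyl groups keep the same ring size; what differs is the 3-carbamoyl-2,2-dimethylcyclobutyl group in place of the 3-hydroxycyclobutyl group. Among the measured compounds shown here, no pair of measured compounds differs in exactly this way, so the size of the step is open.

Since compound 1 stands at the limit of this assay, the step from compound 1 to compound 4 can only be an expectation of a move toward a measurable number, and the estimate here is a modest move downward, an at least 3.3-fold lower number from compound 1 to compound 4 (0.52 log units; beyond the scatter). Compound 4 is expected to give about 3000 nM, within a range from 800 nM to 12000 nM.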

Compound 4, half-maximal inhibitory concentration: 160 nM
Estimate against measurement, compound 4: 19-fold (1.27 log units) above, outside the stated range (below it).
By their numbers in this assay, from the lowest: compound 4; then compound 2; then compound 3. At a limit, above all of these: compound 1.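

Compound 1 stands only at a limit in this assay: the limit of > 10000 nM in this assay, at which 1 of the 4 values shown sits. Among the compounds shown here, putting 3-carbamoyl-2,2-dimethylcyclobutyl in place of 3-hydroxycyclobutyl on a nitrogen on an aromatic ring gives an at least 62-fold lower number from compound 1 to compound 4 (1.79 log units; beyond the scatter), a large step beyond the scatter, and this is the first step between compounds that differ in one place. It shows that, with the core of compound 1 held fixed and the four-membered carbon ring kept, the group on this nitrogen alone can carry the series to a measurable number, with compound 4 at 160 nM.

Since the carbamoyl group and the two methyl groups enter together, the compounds shown cannot divide the step between them, and a cyclobutyl bearing only the carbamoyl group or only the two methyl groups would be needed to separate them. On these data alone, it also stays open what a carboxylic acid or a methyl ester in place of the carbamoyl group would give on this ring, and whether the opposite stereoisomer of the 3-carbamoyl-2,2-dimethylcyclobutyl group would keep the step.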